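Naphthol biaryls: methanesulfonamido for cyano, expected inhibition

This account rests on a few compounds, and the source may have more. Where it says the series, first, only, none or still open, it means among the compounds named here.

Measured so far in an assay for binding affinity to 17-beta-hydroxysteroid dehydrogenase type 2 (Homo sapiens), with a stated time of 20 min, tested at 1 uM; a lower number here means less inhibition, a higher number more inhibition at the concentration tested (going by the name of the read-out):
compound 1 `Oc1cccc2cc(-c3ccccc3)ccc12`: 20%
compound 2 `N#Cc1ccc(-c2ccc3c(O)cccc3c2)cc1`: 12%

Compound 2 gives the lowest of the two numbers in this assay; its nearest neighbour is compound 1, and the step of a number 8 percentage points lower from compound 1 to compound 2 (within the scatter) lies within the scatter, so the two compounds cannot be told apart on these numbers.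

Compound 3 `CS(=O)(=O)Nc1ccc(-c2ccc3c(O)cccc3c2)cc1` is not yet measured. It differs from compound 2 by methanesulfonamido in place of cyano on an aromatic carbon.

Among the measured compounds shown here, no measured step exchanges cyano for methanesulfonamido, so none bears directly on this change. For the measured compounds named here, the only step, a number 8 percentage points lower from compound 1 to compound 2 (within the scatter), shows that replacing hydrogen by cyano on this ring stayed within the scatter. Going by the values given here, with no bearing step, no movement beyond the scatter is expected for compound 3, and the step of a number 3 percentage points higher from compound 2 to compound 3 (within the scatter) is estimated to stay within it. For compound 3 the expected value in this assay is 15%, with a range from 0% to 35%.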

Compound 3, a percentage reported as inhibition, at one concentration (the size of the read-out at that concentration, not a potency): 75%
Estimate against measurement, compound 3: 60 percentage points below; the measured number lies above the stated range.
By their numbers in this assay, from the lowest: compounds 2 and 1 (each within the scatter of the next); then compound 3.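

Working notes on the series: in this assay, the position para to a large group is not indifferent to what it carries, which the cyano step alone could not show. Methanesulfonamido in place of cyano gives a number 63 percentage points higher from compound 2 to compound 3 (beyond the scatter), and methanesulfonamido in place of hydrogen gives a number 55 percentage points higher from compound 1 to compound 3 (beyond the scatter), so the change is large measured against either earlier compound, while those two compounds remain within the scatter of each other. Nothing available explains why this group has such an effect on the read-out.

Going by these compounds, whether an acetamido group, a plain amine or a carboxylic acid at this place would match methanesulfonamido remains open. So does whether ethanesulfonamido, with its longer chain, or methanesulfonamido placed elsewhere on the same ring would keep the number.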